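From methyl to nitro: a step not yet measured

The source may report more compounds than this note shows. Statements on the series, on what has been measured and on what is new or still open speak of the compounds shown alone.

In a functional assay on MCF7 cells (Homo sapiens) for cytotoxicity, read by MTT assay, with a stated time of 48 h (a lower number here means a stronger inhibitor, a higher number a weaker inhibitor), three compounds with a shared core have readings so far. Compound 1 (`CN(C)/C=C/C(=O)c1ccc2c(c1)CCCC2`) gives 29.3 ug/mL as its reading, compound 2 (`O=C(/C=C\Nc1ccccc1)c1ccc2c(c1)CCCC2`) gives 32.2 ug/mL as its reading, and compound 3 (`Cc1ccc(N/C=C\C(=O)c2ccc3c(c2)CCCC3)cc1`) gives 43.6 ug/mL as its reading. All three lie within the usual scatter of one another, so compound 3 stands level with compound 1 and compound 2 on these numbers.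

Compound 4 (`O=C(/C=C\Nc1ccc([N+](=O)[O-])cc1)c1ccc2c(c1)CCCC2`) has not yet been measured. It differs from compound 3 by nitro in place of methyl on an aromatic carbon, para to a large group (nitro in place of methyl on an aromatic carbon). Among the measured compounds shown here, only one measured step bears on this change: a 1.4-fold higher number from compound 2 to compound 3 (0.13 log units; within the scatter) for methyl in place of hydrogen on an aromatic carbon. For the measured compounds named here, no measured compound carries a nitro, so the data offer only this small step as a guide. In this assay no change beyond the scatter is therefore expected. The estimated step is a 1.2-fold lower number from compound 3 to compound 4 (0.10 log units; within the scatter) in size, and its direction is only weakly supported. For compound 4 the estimated value is 35 ug/mL with an expected range from 16 ug/mL to 75 ug/mL in this measurement.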

Compound 4, half-maximal inhibitory concentration: 28.5 ug/mL
For compound 4 the middle estimate is 1.2-fold (0.09 log units) above the measured one; the measured number falls inside the stated range.
By their numbers in this assay, from the lowest: compounds 4, 1, 2 and 3 (each within the scatter of the next).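

In this assay this aromatic carbon, para to a large group, now carries hydrogen, methyl and nitro, and both a 1.5-fold lower number from compound 3 to compound 4 (0.18 log units; within the scatter) and a 1.1-fold lower number from compound 2 to compound 4 (0.05 log units; within the scatter) leave compound 2, compound 3 and compound 4 level with one another. Among the compounds shown here, until now the only change tested here was methyl in place of hydrogen, whereas nitro has 3 heavy atoms and 2 hydrogen-bond acceptors against 1 heavy atom and 0 hydrogen-bond acceptors for methyl, so these readings show that a change of this size at this place can still stay within the scatter. No measurement on these compounds offers an explanation for this level reading.

The compounds shown leave open whether an amine or a carboxylic acid on this same aromatic carbon would also stay level with compound 2 in this assay or move clearly away from it. They also leave open whether nitro would stay level on another carbon of that ring, and whether a longer chain at this place would do the same.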